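The source may hold more compounds than are shown below. What is called first, only, known or untested is meant among the compounds shown, and "the series" means these compounds.

Compounds measured so far in a functional assay on DU-145 cells (Homo sapiens) for inhibition, read by MTT assay, with a stated time of 24 h; a lower number here means a stronger inhibitor, a higher number a weaker inhibitor:

Compound 1, `CCOC(=O)C1=Cc2ccccc2OC1(OCc1cn(-c2ccc(F)cc2)nn1)C(F)(F)F` — 8900 nM
Compound 2, `CCOC(=O)C1=Cc2ccccc2OC1(OCc1cc(-c2ccc(Br)cc2)no1)C(F)(F)F` — 71700 nM

Of these two numbers, compound 2 holds the higher one, so in this assay it is the weaker inhibitor of the pair. Its nearest neighbour is compound 1, whose lower number lies beyond the usual scatter of the measurement, so the two compounds are genuinely told apart.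

The next compound is compound 3, `CCOC(=O)C1=Cc2ccccc2OC1(OCc1cc(-c2ccc(Cl)cc2)no1)C(F)(F)F`. It keeps the shared core and the whole of the side chain of compound 2 and differs in one place: chloro in place of bromo on an aromatic carbon.

Within the data shown here, no step between measured compounds is available for this change, so the expectation rests on the size of the change itself, a single halogen exchanged for another on the same aromatic carbon. Such a change is expected to move this assay by little, if at all, and nothing in the two measured numbers points to a direction. The step from compound 2 to compound 3 is therefore expected to be about a 1.2-fold lower number from compound 2 to compound 3 (0.08 log units; within the scatter), within the scatter. For compound 3 an estimated value of 60000 nM is expected, with a range of 25000 nM to 150000 nM.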

Compound 3, half-maximal inhibitory concentration: 18200 nM
Compound 3: the middle estimate sits 3.3-fold (0.52 log units) above what was measured; the measured number lies below the stated range.
By their numbers in this assay, from the lowest: compound 1; then compound 3; then compound 2.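

In this assay, going from 4-bromophenyl to 4-chlorophenyl gives a 3.9-fold lower number from compound 2 to compound 3 (0.60 log units; beyond the scatter) and makes compound 3 the stronger inhibitor of this pair. This first matched pair shows that the position on the six-membered aromatic ring, para to a large group, responds measurably to the identity of the halogen, even though the exchange swaps one heavy atom for one heavy atom and leaves the counts of hydrogen-bond donors and acceptors unchanged. No measurement shown here accounts for this difference between chloro and bromo.

With only two halogens compared on this carbon, the compounds shown do not tell whether fluoro, a hydrogen, methyl or methoxy there would extend the step seen with chloro, leave the number near that of compound 3, or reverse it. They also leave open whether the same exchange of bromo for chloro would give a similar step with a different side-chain ring on the shared core, such as the triazole-bearing side chain of compound 1.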